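A few compounds are considered here, and "the series" means these few. Any claim that something is new, unique, unknown or untested is made for them only; others in the source may bear on it.

Working notes on the series.

Compound 1 `O=C(O)c1cccc(-c2csc(Nc3ccccc3F)n2)c1`, compound 2 `O=C(O)c1cccc(-c2csc(Nc3ccccc3)n2)c1` and compound 3 `O=C(O)c1cccc(-c2cnc(Nc3ccccc3F)o2)c1` have been run in an ADME assay on microsomes from liver (Mus musculus) for metabolic stability, read by LC-MS, using NADPH; a lower number here means that the compound disappears faster, a higher number that the compound lasts longer. Compound 1 gives 0.532 h, compound 2 gives 0.802 h and compound 3 gives 1.71 h. The difference between the core of compound 2 and the core of compound 3 is not broken down here; their values show compound 3 lasting longer than either compound 2 or compound 1.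

Compound 2 and compound 1 differ in one place: fluoro in place of hydrogen on an aromatic carbon That change made a 1.5-fold lower number from compound 2 to compound 1 (0.18 log units; within the scatter).

Compound 4 `O=C(O)c1cccc(-c2cnc(Nc3ccc(F)cc3F)o2)c1` has not yet been measured in this assay. It differs from compound 3 in one place: fluoro in place of hydrogen on an aromatic carbon Here the entering fluoro sits meta to a fluoro group and para to a large group, whereas in compound 1 it sits ortho to a large group, so this is the same kind of change, not the same one.

For compound 4 the expected step is a 1.3-fold lower number from compound 3 to compound 4 (0.12 log units; within the scatter). This rests on the earlier fluoro step, a 1.5-fold lower number from compound 2 to compound 1 (0.18 log units; within the scatter), which lay within the scatter, with the different place treated as a loose guide only. Compound 4 is therefore estimated at 1.3 h in this assay, between 0.7 h and 2.6 h.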

Compound 4, half-life in the Mus musculus assay: 0.565 h
For compound 4 the middle estimate is 2.3-fold (0.36 log units) above the measured one, and the stated range ends above it.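

In the Mus musculus assay compound 4 gives 0.565 h, the fluoro change gives a 3.0-fold lower number from compound 3 to compound 4 (0.48 log units; beyond the scatter), and set beside the earlier step on the other core it does not separate from it: the same change on two cores in the Mus musculus assay, a 1.5-fold lower number (0.18 log units; within the scatter) from compound 2 to compound 1 and a 3.0-fold lower number (0.48 log units; beyond the scatter) from compound 3 to compound 4, 2.0-fold (0.30 log units) apart, within the scatter of two such steps

The two steps therefore give no ground for calling the effect of this change dependent on the core, and the larger step on the core of compound 3 is not shown to be a real difference between the cores. Two pairs, with the fluoro entering at different places on the ring, also cannot show that the step would carry unchanged to a further core; in a physicochemical assay for solubility, using the shake flask method, measured as kinetic solubility, at pH 7.4 (a lower number here means a less soluble compound, a higher number a more soluble compound), compound 3 gives 55600 nM and compound 4 gives 69000 nM, and the step is a 1.2-fold higher number from compound 3 to compound 4 (0.09 log units; within the scatter), read on one core only.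

On these data alone, it remains open whether chloro or methyl in place of the entering fluoro would give a step of similar size in the Mus musculus assay. As far as these compounds go, it is equally open how the step would read with an amide in place of the carboxylic acid.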